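Compound 4: One Aromatic Group Swapped at the Limit

The source may report more compounds than this note shows. Statements on the series, on what has been measured and on what is new or still open speak of the compounds shown alone.

Compound 1 `Cc1cc(=O)oc2cc(OCc3cn(-c4ccccc4Cl)nn3)ccc12` is the starting point in an ADME assay on Huh-7 cells (Homo sapiens) for cytotoxicity, read by MTT assay, with a stated time of 72 h; on this read-out lower numbers stand for higher toxicity in this test and higher numbers for lower toxicity in this test. Compound 1 gives > 100 ug/mL, which is a limit and not a number. Compound 2 `CC(=O)Nc1ccc(-n2cc(COc3ccc4c(C)cc(=O)oc4c3)nn2)cc1` gives > 100 ug/mL, also a limit. Compound 3 `Cc1cc(=O)oc2cc(OCc3cn(-c4ccc(Oc5ccccc5)cc4)nn3)ccc12` gives > 100 ug/mL, again a limit. No order among these three compounds can be read, so compound 1 has no exact place on the scale.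

Compound 4 `Cc1cc(F)ccc1-n1cc(COc2ccc3c(C)cc(=O)oc3c2)nn1` keeps the core of compound 1 and changes one group: 4-fluoro-2-methylphenyl in place of 2-chlorophenyl on an aromatic nitrogen. Among the compounds with values here, the one measured step, a step that the two limits leave unreadable from compound 2 to compound 3, is a different swap, phenoxy in place of acetamido on an aromatic carbon, and it sets no size to carry over. Within the data shown here, with the limit of > 100 ug/mL in this assay, at which 3 of the 3 values shown sit, as the only guide, no step beyond the usual scatter is expected in this assay, in either direction. The estimated change is a step that the limit leaves unreadable from compound 1 to compound 4. For compound 4 the expected value is 130 ug/mL, with an estimated range of 70 ug/mL to 250 ug/mL, and the assay will most likely report only a limit again.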

Compound 4, half-maximal cytotoxic concentration: > 100 ug/mL
Compound 4 was reported as a limit; the forecaster's own chance of this, stated with the estimate: 85%; the middle value does not contradict the limit.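

Compound 1 and compound 4 are both reported only as a limit, so no step between them can be read: the limit of > 100 ug/mL in this assay, at which 4 of the 4 values shown sit.

The compounds shown leave open where any of them truly stands on the scale, and whether any group on the aromatic nitrogen would give a real number instead of a limit.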